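Side-chain change on compound 2: working notes

This account rests on a few compounds, and the source may have more. Where it says the series, first, only, none or still open, it means among the compounds named here.

In a functional assay on A549 cells (Homo sapiens) for cytotoxicity, read by colorimetric assay and MTT assay (on this read-out higher numbers stand for weaker inhibition and lower numbers for stronger inhibition), compound 1 `COc1ccc2cc(-c3ccccc3)c(O)nc2c1` gives 10000 nM. Compound 2 `COc1ccc(-c2cc3c(OC)cc(OC)cc3n(CC#N)c2=O)cc1` gives 10000 nM, which stands level with compound 1. Compound 3 `COC(=O)CCn1c(=O)c(-c2ccc(OC)cc2)cc2c(OC)cc(OC)cc21` differs from compound 2 by one change, (methoxycarbonyl)methyl in place of cyano on a saturated chain carbon bound to an aromatic nitrogen. Among the measured compounds shown here, no measured pair shows the effect of such a change, so no shift beyond the scatter is expected in this assay. The expected size of the change is no change at the digits printed from compound 2 to compound 3 (within the scatter). For compound 3 the estimate is 10000 nM, with an expected range from 4000 nM to 20000 nM.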

Compound 3, half-maximal inhibitory concentration: 10000 nM
Compound 3: the middle estimate sits on the measured number at the digits printed, within the range that was stated.
By their numbers in this assay, from the lowest: compounds 1, 2 and 3 (each within the scatter of the next).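

In this assay the first step read at this place is no change at the digits printed from compound 2 to compound 3 (within the scatter) for (methoxycarbonyl)methyl in place of cyano on a saturated chain carbon bound to an aromatic nitrogen. Cyanomethyl and 2-(methoxycarbonyl)ethyl therefore cannot be told apart on this read-out, and the ester-bearing chain is tolerated here without any separation from the nitrile-bearing one. As far as these compounds go, whether a carboxylic acid or an amine at the end of this chain, or a longer chain, would read differently remains open. No supporting data bear on why these two side chains read alike.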